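A few compounds are considered here, and "the series" means these few. Any claim that something is new, unique, unknown or untested is made for them only; others in the source may bear on it.

Measured in a functional assay on MDA-MB-231 cells (Homo sapiens) for cytotoxicity, read by MTT assay, with a stated time of 24 h; a higher number here means a weaker inhibitor, a lower number a stronger inhibitor (lower numbers mean stronger inhibition):

- Compound 1 `O=C1/C(=C/c2ccccc2F)CN(Cc2cn(Cc3ccccc3F)nn2)C/C1=C\c1ccccc1F` gives 16000 nM
- Compound 2 `O=C1/C(=C/c2ccccc2F)CN(Cc2cn(Cc3cccc(Cl)c3)nn2)C/C1=C\c1ccccc1F` gives 12000 nM
- Compound 3 `COc1ccc(/C=C2\CN(Cc3cn(Cc4ccc(F)cc4)nn3)C/C(=C\c3ccc(OC)cc3)C2=O)cc1` gives 70700 nM

Compound 2 stands level with compound 1 at the low end of these numbers, and compound 3 stands clearly higher. Compound 4 `O=C1/C(=C/c2ccccc2F)CN(Cc2cn(Cc3ccccc3Cl)nn2)C/C1=C\c1ccccc1F` differs from compound 2 by one change (2-chlorophenyl in place of 3-chlorophenyl on a saturated chain carbon bound to an aromatic nitrogen): 2-chlorophenyl in place of 3-chlorophenyl on a saturated chain carbon bound to an aromatic nitrogen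

Within the data shown here, one measured step bears on this place (a 1.3-fold lower number from compound 1 to compound 2 (0.12 log units; within the scatter)), and it stays within the scatter. Among the measured compounds shown here, compound 3 offers no such step. No step beyond the scatter is therefore expected in this assay in either direction. The expected step is a 1.1-fold higher number from compound 2 to compound 4 (0.03 log units; within the scatter) (an estimate). The estimate for compound 4 is 13000 nM (expected range 6000 nM to 28000 nM).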

Compound 4, half-maximal inhibitory concentration: 16500 nM
For compound 4 the middle estimate is 1.3-fold (0.10 log units) below the measured one; the range from low to high includes it.
By their numbers in this assay, from the lowest: compounds 2, 1 and 4 (each within the scatter of the next); then compound 3.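

In this assay, 2-chlorophenyl in place of 3-chlorophenyl gives a 1.4-fold higher number from compound 2 to compound 4 (0.14 log units; within the scatter), so the place of the chlorine on this group leaves the number level. Chloro in place of fluoro on an aromatic carbon gives a 1.0-fold higher number from compound 1 to compound 4 (0.01 log units; within the scatter), and compound 1 and compound 4 also stand level. No evidence on hand explains these results.

From the compounds shown here alone, whether an amine or a carboxylic acid in place of the 2-chlorophenyl would shift the number beyond the scatter stays open. So does the source of the higher number of compound 3, which differs from the others in more than one place.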